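Swapping the Substituent on a Fused Ring Core

The source may report more compounds than this note shows. Statements on the series, on what has been measured and on what is new or still open speak of the compounds shown alone.

Measured so far:
- compound 1 `COc1ccc2[nH]c(-c3cccc(C)n3)nc2c1`: 40%
- compound 2 `CCc1ccc(-c2nc3cc(Cl)ccc3[nH]2)nc1`: -2%
- compound 3 `CCc1ccc(-c2nc3cc(O)ccc3[nH]2)nc1`: 25%

In a functional assay on the whole organism with Rattus norvegicus as the target, read by paw edema, with a stated time of 3 h, at a dose of 100 mg/kg by the oral route (on this read-out lower numbers stand for less inhibition and higher numbers for more inhibition at the one dose given (going by the name of the read-out)), compound 3 gives 25%, the second highest of the three numbers. Compound 1 gives 40%, a gap beyond the scatter. Compound 2 gives -2%, also a gap beyond the scatter. Within the data shown here, the one step between two compounds that differ in a single place is the one from compound 2 to compound 3, with hydroxy in place of chloro on an aromatic carbon: a number 27 percentage points higher from compound 2 to compound 3 (beyond the scatter).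

Compound 4 `CCc1ccc(-c2nc3cc([N+](=O)[O-])ccc3[nH]2)nc1` has not yet been measured. It differs from compound 3 in one place: nitro in place of hydroxy on an aromatic carbon. Among the measured compounds shown here, no measured step shows what nitro does at this position, so the only guide is that the step from compound 2 to compound 3 shows the read-out moving well beyond the scatter when this group is exchanged. The direction for nitro is therefore open. The estimate for compound 4 in this assay is 15%, within a range of -10% to 40%, which would mean an expected step of a number 10 percentage points lower from compound 3 to compound 4 (within the scatter).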

Compound 4, a percentage reported as inhibition, in the whole organism at one dose (the size of the read-out at that dose, not a potency): -5%
Beside the measured number, compound 4's estimate is 20 percentage points above it; measured number inside the range.
By their numbers in this assay, from the lowest: compounds 4 and 2 (each within the scatter of the next); then compound 3; then compound 1.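

In this assay, the change at this position on the shared core now has a second and a third point of comparison: a number 30 percentage points lower from compound 3 to compound 4 (beyond the scatter), with nitro in place of hydroxy, while a number 3 percentage points lower from compound 2 to compound 4 (within the scatter), with nitro in place of chloro. Among these three groups on the same core, then, only hydroxy stands apart, and chloro and nitro cannot be told from each other on this read-out. Nothing available explains why hydroxy differs from the other two groups.

Still open, on these data alone, is whether an amine or a carboxylic acid at this position would give a number like that of hydroxy or like those of chloro and nitro. Also open, as far as these compounds go, is how a longer chain in place of the ethyl group would affect the read-out.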